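This account rests on a few compounds, and the source may have more. Where it says the series, first, only, none or still open, it means among the compounds named here.

Of the compounds shown here, three sharing one core have been tested in a functional assay (Homo sapiens) for inhibition of Nucleic Acid, tested at 100 uM; on this read-out higher numbers stand for more inhibition at the one concentration tested (going by the name of the read-out) and lower numbers for less inhibition. Compound 1, `CN(C)c1[nH]ccc2ncnc1-2`, gives 8%. Compound 2, `[N-]=[N+]=Nc1[nH]ccc2ncnc1-2`, gives 20%. Compound 3, `CCNc1[nH]ccc2ncnc1-2`, gives 3%, the lowest of the three numbers shown, although the gap to compound 1 is small: the step of a number 5 percentage points lower from compound 1 to compound 3 (within the scatter) stays within the scatter, while the step of a number 17 percentage points lower from compound 2 to compound 3 (beyond the scatter) lies beyond it.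

Compound 4, `Sc1[nH]ccc2ncnc1-2`, has not yet been measured in this assay. It differs from compound 3 in one place: sulfanyl in place of ethylamino on an aromatic carbon.

Two measured steps touch the same position of the core, the exchange of dimethylamino for ethylamino from compound 1 to compound 3 and the exchange of azido for ethylamino from compound 2 to compound 3, of the sizes given above. Going by the values given here, neither involves sulfanyl, so no measured step tells directly what this group does here. All three numbers are low, and the two amino-type groups sit within the scatter of each other. For compound 4 the expectation is therefore a step of a number 5 percentage points higher from compound 3 to compound 4 (within the scatter), which is to say no change beyond the scatter, with the number estimated at 8% and a range from 0% to 25%.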

Compound 4, a percentage reported as inhibition, at one concentration (the size of the read-out at that concentration, not a potency): 26%
The estimate for compound 4 lay 18 percentage points below the measured number; the measured number lies above the stated range.
By their numbers in this assay, from the lowest: compounds 3 and 1 (each within the scatter of the next); then compounds 2 and 4 (each within the scatter of the next).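

In this assay, this position on an aromatic carbon proves more sensitive than the two amino-type groups alone suggested: sulfanyl brings a number 23 percentage points higher from compound 3 to compound 4 (beyond the scatter) and a number 18 percentage points higher from compound 1 to compound 4 (beyond the scatter) as well. The other comparison, a number 6 percentage points higher from compound 2 to compound 4 (within the scatter) between azido and sulfanyl, leaves these two groups indistinguishable here, so the four compounds fall into two pairs, with compounds 2 and 4 above compounds 1 and 3. Ethylamino and sulfanyl carry the same counts of hydrogen-bond donors and acceptors, so those counts do not separate compound 3 from compound 4, and the difference in heavy atoms is the other listed change.

Nothing measured here bears on why sulfanyl and azido stand above the amino-type groups. Still open, on these data alone, is whether a hydroxyl, a methylsulfanyl group, an unsubstituted amine or a halogen such as chlorine at this position would join the upper pair or the lower one, and whether any group would lift the number far beyond these modest values at the one concentration tested.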